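The source may report more compounds than this note shows. Statements on the series, on what has been measured and on what is new or still open speak of the compounds shown alone.

Compound 1 `Cc1nc(N2CCN(C3CCCC3)CC2)nc2ccc(NC(=O)COc3ccc(Cl)cc3)cc12` carries a 4-cyclopentylpiperazin-1-yl group on the shared core. In an assay on CHO-K1 cells for displacement of a labelled ligand from melanin-concentrating hormone receptor 1 (Homo sapiens), with a stated time of 2 h (a higher number here means a weaker inhibitor, a lower number a stronger inhibitor), compound 1 gives 96 nM, the highest of the two numbers available. Compound 2 `Cc1nc(N2CCN(C3CCOCC3)CC2)nc2ccc(NC(=O)COc3ccc(Cl)cc3)cc12` gives 45 nM, and a 2.1-fold lower number from compound 1 to compound 2 (0.33 log units; beyond the scatter). Compound 3 `Cc1nc(N2CCC(O)CC2)nc2ccc(NC(=O)C(C)(C)Oc3ccc(Cl)cc3)cc12` differs from compound 1 in several places. In this assay compound 3 gives > 10000 nM, a limit of this assay rather than a number. Compound 4 `Cc1nc(N2CCC(C)(O)CC2)nc2ccc(NC(=O)COc3ccc(Cl)cc3)cc12` is still to be measured: 4-hydroxy-4-methylpiperidin-1-yl in place of 4-cyclopentylpiperazin-1-yl on an aromatic carbon. For the measured compounds named here, only the step from compound 1 to compound 2 concerns a change on this ring, and it was modest; compound 3 cannot be read as a single step. Compound 4 is therefore expected to give 800 nM, between 100 nM and 10000 nM. This estimate amounts to an 8.3-fold higher number from compound 1 to compound 4 (0.92 log units; beyond the scatter).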

Compound 4, half-maximal inhibitory concentration: 237 nM
The estimate for compound 4 lay 3.4-fold (0.53 log units) above the measured number; measured number inside the range.
By their numbers in this assay, from the lowest: compound 2; then compound 1; then compound 4. At a limit, above all of these: compound 3.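

Replacing the 4-cyclopentylpiperazin-1-yl group on this aromatic carbon with the smaller 4-hydroxy-4-methylpiperidin-1-yl group has only a modest effect: a 2.5-fold higher number from compound 1 to compound 4 (0.39 log units; beyond the scatter). Neither the cyclopentyl ring nor a piperazine is therefore needed for compound 4 to give a measurable number in this assay. Nothing shown here accounts for the size of this step.

Which part of the new group matters, the hydroxyl or the methyl, stays open. So does what a plain piperidin-1-yl, a morpholin-4-yl or a 4-aminopiperidin-1-yl group would give here.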